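The compounds below may be only part of what the source reports. "The series", "measured", "known", "first", "only" and "open" are said of these compounds alone.

Three compounds have so far been measured in a functional assay on CCRF-CEM cells (Homo sapiens) for antiproliferative activity; a lower number here means a stronger inhibitor, a higher number a weaker inhibitor:

compound 1 `COc1cc(C(=O)c2sc(-c3ccc(Cl)cc3)cc2N)cc(OC)c1OC`, 70 nM
compound 2 `COc1cc(C(=O)c2sc(-c3ccsc3)cc2N)cc(OC)c1OC`, 9.6 nM
compound 3 `COc1cc(C(=O)c2sc(-c3ccc([N+](=O)[O-])cc3)cc2N)cc(OC)c1OC`, 99 nM

Compound 3 gives the highest number of the three. Its nearest neighbour is compound 1, and the step of a 1.4-fold higher number from compound 1 to compound 3 (0.15 log units; within the scatter) lies within the scatter, so the two cannot be told apart. Compound 2 stands furthest away: the step of a 10-fold higher number from compound 2 to compound 3 (1.01 log units; beyond the scatter) is large and beyond the scatter.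

Compound 4 `COc1ccc(-c2cc(N)c(C(=O)c3cc(OC)c(OC)c(OC)c3)s2)cc1` differs from compound 3 in one place only: methoxy in place of nitro on an aromatic carbon. For the measured compounds named here, the measured step that bears most directly on this change is the one from compound 1 to compound 3, which also exchanges one group for another on an aromatic carbon of the 4-substituted phenyl ring and stayed within the scatter a 1.4-fold higher number from compound 1 to compound 3 (0.15 log units; within the scatter). The steps of a 7.3-fold lower number from compound 1 to compound 2 (0.86 log units; beyond the scatter) and a 10-fold higher number from compound 2 to compound 3 (1.01 log units; beyond the scatter) replace the whole ring by thiophen-3-yl and bear less on a single group swap. On that basis the step of a 1.2-fold lower number from compound 3 to compound 4 (0.09 log units; within the scatter) is expected to stay within the scatter, with no clear direction.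

Compound 4 is therefore estimated at 80 nM in this assay, with a range from 30 nM to 220 nM.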

Compound 4, half-maximal inhibitory concentration: 19 nM
Estimate against measurement, compound 4: 4.2-fold (0.62 log units) above; measured number outside the range, below it.
By their numbers in this assay, from the lowest: compounds 2 and 4 (each within the scatter of the next); then compounds 1 and 3 (each within the scatter of the next).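

Within this assay, exchanging a single group on the phenyl ring can clearly move the number: methoxy in place of nitro gives a modest change beyond the scatter (a 5.2-fold lower number from compound 3 to compound 4 (0.72 log units; beyond the scatter)), and methoxy in place of chloro does the same (a 3.7-fold lower number from compound 1 to compound 4 (0.57 log units; beyond the scatter)), whereas the earlier exchange of chloro for nitro stayed within the scatter. This place, para to a large group, therefore responds to what it carries, and among these compounds methoxy is the group that separates from the other two, while chloro and nitro cannot be told apart. With methoxy in place, the 4-methoxyphenyl compound can no longer be told apart from the thiophen-3-yl compound (a 2.0-fold higher number from compound 2 to compound 4 (0.30 log units; within the scatter)), so the whole-ring change is not the only route to the lower numbers; nothing available explains why these groups differ.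

From the compounds shown here alone, only chloro, nitro and methoxy are compared at this place, so it stays open whether a hydroxyl, an amine or a longer chain such as ethoxy would follow methoxy or the other two. Going by these compounds, it is also open whether methoxy at other places on this ring would give the same result.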